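The source may hold more compounds than are shown below. What is called first, only, known or untested is meant among the compounds shown, and "the series" means these compounds.

Measured compounds and their values in a functional assay on DU-145 cells (Homo sapiens) for inhibition, read by trypan blue exclusion, with a stated time of 96 h; on this read-out higher numbers stand for weaker inhibition of growth and lower numbers for stronger inhibition of growth:
- compound 1, `Cc1ccc(CS/C(=C/c2ccccc2F)C(=O)c2ccc(Cl)cc2)cc1`: 10000 nM
- compound 2, `Cc1ccc(CS/C(=C/c2ccc(Br)cc2)C(=O)c2ccc(Cl)cc2)cc1`: 10000 nM
- compound 3, `Cc1ccc(CS/C(=C/c2c(O)cc(O)cc2O)C(=O)c2ccc(Cl)cc2)cc1`: 50000 nM

Compound 3 has the highest number of the three in this assay. Its nearest neighbour is compound 1, with a 5.0-fold higher number from compound 1 to compound 3 (0.70 log units; beyond the scatter), and compound 2 stands at the same distance, with a 5.0-fold higher number from compound 2 to compound 3 (0.70 log units; beyond the scatter). Between compound 1 and compound 2 there is no change at the digits printed from compound 1 to compound 2 (within the scatter), so the two halogen-bearing rings behave alike and the trihydroxy ring alone carries the shift.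

Compound 4, `Cc1ccc(CS/C(=C/c2ccc(O)cc2)C(=O)c2ccc(Cl)cc2)cc1`, is not yet measured. It differs from compound 3 in one place: 4-hydroxyphenyl in place of 2,4,6-trihydroxyphenyl on a double-bonded chain carbon bound to a double-bonded chain carbon. Two of the measured steps bear on this change, the steps from compound 1 and from compound 2 to compound 3, both of them modest and both pointing the same way: the ring with three hydroxyls gives a higher number than a ring without them. Compound 4 keeps one hydroxyl and sheds two, so the step from compound 3 to compound 4 is expected to run back toward the values of compound 1 and compound 2, though perhaps not all the way, with a 2.5-fold lower number from compound 3 to compound 4 (0.40 log units; beyond the scatter). Compound 4 is therefore estimated at 20000 nM, within a range from 8000 nM to 60000 nM.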

Compound 4, concentration for 50% growth inhibition: 10000 nM
Compound 4: the middle estimate sits 2.0-fold (0.30 log units) above what was measured; the measured number falls inside the stated range.
By their numbers in this assay, from the lowest: compounds 1, 2 and 4 (each within the scatter of the next); then compound 3.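

With 4-hydroxyphenyl in place of 2,4,6-trihydroxyphenyl on a double-bonded chain carbon bound to a double-bonded chain carbon, this assay gives a 5.0-fold lower number from compound 3 to compound 4 (0.70 log units; beyond the scatter), so one hydroxy group on this ring is enough to leave the shift seen with compound 3 absent. Hydroxy in place of bromo on an aromatic carbon gives no change at the digits printed from compound 2 to compound 4 (within the scatter), and 4-hydroxyphenyl in place of 2-fluorophenyl gives no change at the digits printed from compound 1 to compound 4 (within the scatter), which places a hydroxy-bearing ring alongside the two halogen-bearing rings and shows that, among these compounds, a hydroxy group as such does not set compound 3 apart. Nothing available here accounts for why the 2,4,6-trihydroxyphenyl ring alone stands apart.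

As far as these compounds go, whether the shift of compound 3 needs the full set of hydroxy groups or would already appear with a dihydroxyphenyl ring stays open. Also open, from the compounds shown here alone, is how a methoxy group, an amine or a carboxylic acid would read on this ring, and whether any group here could bring the number below that shared by the other three compounds.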